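A few compounds are considered here, and "the series" means these few. Any claim that something is new, unique, unknown or untested is made for them only; others in the source may bear on it.

Working notes on the series, read in a functional assay on RL cells (Homo sapiens) for cytotoxicity, with a stated time of 48 h; on this read-out higher numbers stand for weaker inhibition and lower numbers for stronger inhibition. Compound 1 (`COc1cc(OC)c(C(=O)/C=C/c2ccccc2OC)c(OC)c1`) gives 9000 nM, compound 2 (`COc1cc(OC)c(C(=O)/C=C/c2ccccc2SC)c(OC)c1`) gives 8300 nM, and compound 3 (`COc1cc(OC)c(C(=O)/C=C/c2ccccc2)c(OC)c1`) gives 6900 nM. Compound 2 thus stands within the scatter of both other compounds, and the three are not separated. The next structure is compound 4 (`COc1cc(OC)c(C(=O)/C=C/c2ccc(Cl)cc2)c(OC)c1`), which differs from compound 2 as follows: 4-chlorophenyl in place of 2-(methylsulfanyl)phenyl on a double-bonded chain carbon bound to a double-bonded chain carbon. In words, 4-chlorophenyl stands in place of 2-(methylsulfanyl)phenyl on a double-bonded chain carbon bound to a double-bonded chain carbon.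

Among the measured compounds shown here, three measured steps bear on this change: a 1.2-fold lower number from compound 2 to compound 3 (0.08 log units; within the scatter), a 1.1-fold lower number from compound 1 to compound 2 (0.04 log units; within the scatter) and a 1.3-fold lower number from compound 1 to compound 3 (0.12 log units; within the scatter). All lie within the scatter, and the closest is the removal of methylsulfanyl. For the measured compounds named here, no measured compound carries 4-chlorophenyl, so the effect of that group remains untested. No shift beyond the scatter is therefore expected in this assay. The estimated step is a 1.4-fold lower number from compound 2 to compound 4 (0.14 log units; within the scatter). For compound 4 the expected value is 6000 nM, within an estimated range of 2500 nM to 12000 nM.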

Compound 4, half-maximal inhibitory concentration: 6500 nM
For compound 4 the middle estimate is 1.1-fold (0.03 log units) below the measured one; the measured number falls inside the stated range.
By their numbers in this assay, from the lowest: compounds 4, 3, 2 and 1 (each within the scatter of the next).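

In this assay, among the compounds shown here, chloro in place of hydrogen on an aromatic carbon gives a 1.1-fold lower number from compound 3 to compound 4 (0.03 log units; within the scatter), so this is the first reading of a chloro group, and it does not separate the pair. The same holds for the two larger replacements on the double-bonded chain carbon: 4-chlorophenyl gives a 1.3-fold lower number from compound 2 to compound 4 (0.11 log units; within the scatter) in place of 2-(methylsulfanyl)phenyl and a 1.4-fold lower number from compound 1 to compound 4 (0.14 log units; within the scatter) in place of 2-methoxyphenyl, so all four compounds remain unseparated, now with a chlorine-bearing ring among them. No measurement is available that would explain these numbers.

From the compounds shown here alone, whether an amine or a carboxylic acid on this aromatic ring would move the number beyond the scatter remains open. Also open, going by these compounds, is whether any change to the shared core would do so.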